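Pyrrolidinyl for Methoxy on a Propargyl Chain, Second Core

This account rests on a few compounds, and the source may have more. Where it says the series, first, only, none or still open, it means among the compounds named here.

Compound 1 `COCC#Cc1cc2ncnc(Nc3ccc(OCc4cccc(F)c4)c(Cl)c3)c2s1` was tested in an ADME assay on HepG2 cells (Homo sapiens) for cytotoxicity; on this read-out higher numbers stand for lower toxicity in this test and lower numbers for higher toxicity in this test. Compound 1 reaches only the limit of the assay, > 33 uM. Compound 2 `Fc1cccc(COc2ccc(Nc3ncnc4cc(C#CCN5CCCC5)sc34)cc2Cl)c1` gives 4.9 uM in this assay. The change between them is pyrrolidin-1-yl in place of methoxy on a saturated chain carbon bound to a triple-bonded carbon, and it made an at least 6.7-fold lower number from compound 1 to compound 2 (0.82 log units; beyond the scatter); the step is stated as a bound because compound 1 sits at the limit of > 33 uM in this assay, at which 1 of the 3 values shown sits. Compound 3 `COCC#Cc1cc2c(Nc3ccc(OCc4cccc(F)c4)c(Cl)c3)ncnc2s1` carries the same atoms as compound 1 joined differently, and the difference between the two cores is not broken down here. In this assay compound 3 gives 9.5 uM. Compound 4 `Fc1cccc(COc2ccc(Nc3ncnc4sc(C#CCN5CCCC5)cc34)cc2Cl)c1` differs from compound 3 by pyrrolidin-1-yl in place of methoxy on a saturated chain carbon bound to a triple-bonded carbon, the same change as between compound 1 and compound 2. Resting on the step of an at least 6.7-fold lower number from compound 1 to compound 2 (0.82 log units; beyond the scatter), the move from compound 3 to compound 4 is expected to be a 4.8-fold lower number from compound 3 to compound 4 (0.68 log units; beyond the scatter). Compound 4 is therefore estimated at 2 uM in this assay, between 0.7 uM and 6 uM.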

Compound 4, half-maximal toxic concentration: > 30 uM
Compound 4 gave a limit, no number; the forecaster's own chance of this, stated with the estimate: 5%; middle value at least 15-fold (1.17 log units) from the limit.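

In this assay, pyrrolidin-1-yl in place of methoxy gave an at least 3.1-fold higher number from compound 3 to compound 4 (0.49 log units; beyond the scatter), so the change did not keep its direction when carried from one core to the other: the same change on two cores in this assay, an at least 6.7-fold lower number (0.82 log units; beyond the scatter) from compound 1 to compound 2 and an at least 3.1-fold higher number (0.49 log units; beyond the scatter) from compound 3 to compound 4, at least 21-fold (1.32 log units) apart, beyond the scatter of two such steps. This step is only a bound, since compound 4 reaches a limit of the assay and not a number: the limit of > 30 uM in this assay, at which 1 of the 4 values shown sits. The earlier step is likewise a bound, set by the limit of compound 1, so the two steps show that the outcome of this change differed on these two cores but not why, nor the true size of either step: the limit of > 33 uM in this assay, at which 1 of the 4 values shown sits.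

From the compounds shown here alone, it remains open whether a morpholine or a dimethylamino group in the same place would behave as pyrrolidin-1-yl does on each core. The same question stands for a longer chain carrying the amine.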